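Moving the ring nitrogen of the pyridyl group once more

A few compounds are considered here, and "the series" means these few. Any claim that something is new, unique, unknown or untested is made for them only; others in the source may bear on it.

Three compounds share one core and differ only in the aromatic group on an amine nitrogen in a ring. Compound 1 `O=C(CN1CCN(c2cccc(F)c2)CC1)Nc1nc2c(s1)CCCC2` carries a 3-fluorophenyl group; in an assay on isolated protein for inhibition of long-chain fatty acid transport protein 1 (Mus musculus), read by scintillation counting, with a stated time of 20 min (on this read-out higher numbers stand for weaker inhibition and lower numbers for stronger inhibition), compound 1 gives only the limit > 10000 nM, not a number. Compound 2 `O=C(CN1CCN(c2ccncc2)CC1)Nc1nc2c(s1)CCCC2` carries a pyridin-4-yl group; in this assay compound 2 likewise gives only the limit > 10000 nM. Compound 3 `O=C(CN1CCN(c2ccccn2)CC1)Nc1nc2c(s1)CCCC2` carries a pyridin-2-yl group, and in this assay compound 3 gives 4900 nM. Among the measured compounds shown here, compound 3 thus stands as the only compound with a number rather than a limit; the steps of an at least 2.0-fold lower number from compound 1 to compound 3 (0.30 log units; that floor lies within the scatter) and an at least 2.0-fold lower number from compound 2 to compound 3 (0.30 log units; that floor lies within the scatter) both lie at the limit of > 10000 nM in this assay, at which 2 of the 3 values shown sit, and read only as a floor. The step that the two limits leave unreadable from compound 1 to compound 2 cannot be read at all.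

Compound 4 `O=C(CN1CCN(c2cccnc2)CC1)Nc1nc2c(s1)CCCC2` differs from compound 3 by pyridin-3-yl in place of pyridin-2-yl on an amine nitrogen in a ring. The steps from compound 1 and compound 2 to compound 3 show that the other two aromatic groups gave limits, so compound 4 is expected to give a weaker or unmeasurable number, estimated as 8000 nM within 3000 nM to 20000 nM. The expected step is therefore a 1.6-fold higher number from compound 3 to compound 4 (0.21 log units; within the scatter), toward weaker inhibition.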

Compound 4, half-maximal inhibitory concentration: > 10000 nM
Compound 4: a limit, no number (the forecaster's own chance of this, stated with the estimate: 50%); middle value at least 1.2-fold (0.09 log units) from the limit.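

Pyridin-3-yl and pyridin-2-yl have the same atoms and the same counted features, yet this change gives an at least 2.0-fold higher number from compound 3 to compound 4 (0.30 log units; that floor lies within the scatter). That step is only a floor, so it does not establish a real difference, but in this assay pyridin-2-yl remains the only group shown on this amine nitrogen that gives a number rather than a limit. Going by these compounds, the true size of this step is unknown, and the steps among compound 1, compound 2 and compound 4 cannot be read, because all three values stop at the same limit: the limit of > 10000 nM in this assay, at which 3 of the 4 values shown sit.

On these data alone, whether compound 3 truly differs from the other three therefore stays open. Also open, as far as these compounds go, is how a pyrimidin-2-yl group, or a pyridin-2-yl group carrying a methyl group, would read in this assay.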